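The compounds below may be only part of what the source reports. "The series", "measured", "known", "first", "only" and "open" are said of these compounds alone.

Compound 1 `CC(C)Cc1ccc2c(NCCCNCc3ccco3)ccnc2c1` gives 9.47 in a physicochemical assay for acid dissociation. Compound 2 `COc1ccc(-c2ccc3c(NCCCNCc4ccco4)ccnc3c2)cc1` gives 9.47 in this assay, and compound 3 `Fc1ccc(Cc2ccc3c(NCCCNCc4ccco4)ccnc3c2)cc1` gives 9.47. The three measured steps, no change at the digits printed from compound 1 to compound 2 (within the scatter), no change at the digits printed from compound 1 to compound 3 (within the scatter) and no change at the digits printed from compound 2 to compound 3 (within the scatter), all alter the substituent on the aromatic carbon of the shared core and leave the read-out where it is, so compound 1 stands level with compounds 2 and 3 in this assay.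

Compound 4 `COc1cccc(CNCCCNc2ccnc3cc(CC(C)C)ccc23)c1O` is not yet measured. Its change from compound 1 is 2-hydroxy-3-methoxyphenyl in place of furan-2-yl on a saturated chain carbon bound to an amine nitrogen. Among the compounds with values here, this change sits at the other end of the molecule from all three measured steps; none of them touches the saturated chain carbon bound to the amine nitrogen, so no measured step bears directly on it. Within the data shown here, the only guide is that the amine itself is kept, and that the substitutions made so far have left this assay unmoved across compounds 1, 2 and 3. The step of a number 0.03 log units higher from compound 1 to compound 4 (within the scatter) is therefore expected to stay within the scatter or only a little beyond it. The estimate for compound 4 is 9.5, in the range 9 to 10.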

Compound 4, acid dissociation constant: 9.47
The estimate for compound 4 lay 0.03 log units above the measured number; measured number inside the range.
By their numbers in this assay, from the lowest: compounds 1, 2, 3 and 4 (each within the scatter of the next).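

At the saturated chain carbon bound to an amine nitrogen, 2-hydroxy-3-methoxyphenyl in place of furan-2-yl reads in this assay as no change at the digits printed from compound 1 to compound 4 (within the scatter), so the read-out now holds for a change at this position as well as for those on the aromatic carbon of the shared core. The exchange is not a small one by the counts: a five-membered aromatic ring with 1 hetero atom gives way to a six-membered aromatic ring of carbon only, carrying 1 hydrogen-bond donor. No supporting data bear on why the read-out holds.

Open, as far as these compounds go, is whether an entering group with a net charge, such as a carboxylic acid or a second amine, would behave the same way at this carbon. Also open, from the compounds shown here alone, is the effect of a longer chain between the two nitrogens of the shared linker.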